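The source may hold more compounds than are shown below. What is called first, only, known or untested is meant among the compounds shown, and "the series" means these compounds.

In a functional assay on HepG2 cells (Homo sapiens) for inhibition, read by MTT assay, with a stated time of 72 h (on this read-out lower numbers stand for stronger inhibition and higher numbers for weaker inhibition), compound 3 `Nc1ncnc2c1c(-c1cnc3[nH]ccc3c1)nn2CCCCC(=O)NO` gives 36700 nM, the higher of the two true numbers, while compound 2 `Nc1ncnc2c1c(-c1cnc3[nH]ccc3c1)nn2CCCCCCCCC(=O)NO` gives 3050 nM. Compound 1 `Nc1ncnc2c1c(-c1cnc3[nH]ccc3c1)nn2CC(=O)NO` gives > 150000 nM, which is a limit and not a number. Compound 4 `Nc1ncnc2c1c(-c1cnc3[nH]ccc3c1)nn2CCCCCC(=O)NO` differs from compound 3 by (hydroxycarbamoyl)methyl in place of hydroxycarbamoyl on a saturated chain carbon, four bonds along the chain from an aromatic nitrogen. Among the compounds with values here, two measured steps bear on this change, an at least 4.0-fold lower number from compound 1 to compound 3 (0.61 log units; beyond the scatter) and a 12-fold higher number from compound 2 to compound 3 (1.08 log units; beyond the scatter), and both put the lower number on the longer chain. The present lengthening is smaller than the one separating the two measured compounds, so only a small fall is expected. The expected step in this assay is a 2.0-fold lower number from compound 3 to compound 4 (0.31 log units; beyond the scatter). Compound 4 is estimated at 18000 nM, with an expected range of 6000 nM to 45000 nM.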

Compound 4, half-maximal inhibitory concentration: 12900 nM
Estimate against measurement, compound 4: 1.4-fold (0.14 log units) above; measured number inside the range.
By their numbers in this assay, from the lowest: compound 2; then compound 4; then compound 3. At a limit, above all of these: compound 1.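

In this assay a short lengthening of the chain already registers: a 2.8-fold lower number from compound 3 to compound 4 (0.45 log units; beyond the scatter) shows that the number falls in a small step too, not only in the large ones. With a 4.2-fold higher number from compound 2 to compound 4 (0.63 log units; beyond the scatter) still to go, compound 4 lies between compound 3 and compound 2 in the series. Compound 1 gives > 150000 nM as a limit, so an at least 11-fold lower number from compound 1 to compound 4 (1.06 log units; beyond the scatter) is a bound and not a size.

As far as these compounds go, whether a longer chain than that of compound 2 lowers the number further remains open. So does whether a carboxylic acid or an amine at the chain end would keep the trend.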